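Arylidene ketone series: chloro to methyl on the pendant ring

The source may report more compounds than this note shows. Statements on the series, on what has been measured and on what is new or still open speak of the compounds shown alone.

Measured in a functional assay on L1210 cells (Mus musculus) for inhibition; a lower number here means a stronger inhibitor, a higher number a weaker inhibitor:
- compound 1 `O=C1/C(=C/c2ccc(Cl)c(Cl)c2)CCCc2ccccc21` gives 45700 nM
- compound 2 `O=C1/C(=C/c2ccccc2Cl)Cc2ccccc21` gives 152000 nM
- compound 3 `O=C1/C(=C/c2ccc(Cl)cc2Cl)CCCc2ccccc21` gives only the assay limit > 500000 nM

Compound 2 holds the highest of the two numbers shown; the nearest is compound 1, whose number is lower by a margin beyond the scatter. For compound 3 the limit is all that is known (the limit of > 500000 nM in this assay, at which 1 of the 3 values shown sits).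

Compound 4 `Cc1ccccc1/C=C1\Cc2ccccc2C1=O` is to be measured in this assay. It differs from compound 2 by methyl in place of chloro on an aromatic carbon. Going by the values given here, no measured pair shows this exchange, so no step size can be read off; a change not beyond the scatter is expected, in either direction. Compound 4 is estimated at 150000 nM (range 50000 nM to 450000 nM), which means an expected step of a 1.0-fold lower number from compound 2 to compound 4 (0.01 log units; within the scatter).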

Compound 4, half-maximal inhibitory concentration: 208000 nM
For compound 4 the middle estimate is 1.4-fold (0.14 log units) below the measured one; measured number inside the range.
By their numbers in this assay, from the lowest: compound 1; then compounds 2 and 4 (each within the scatter of the next). At a limit, above all of these: compound 3.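

In this assay, the series gives its first one-place comparison: a 1.4-fold higher number from compound 2 to compound 4 (0.14 log units; within the scatter) with methyl in place of chloro on an aromatic carbon, ortho to a large group. At this position the two groups cannot be told apart in this assay. Nothing measured here bears on why they read alike.

From the compounds shown here alone, whether a methoxy group or an amine at this position would read differently remains open. So does whether the same exchange would hold on the core of compound 1.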